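Halogen swap on the fused ring of compound 2

The source may report more compounds than this note shows. Statements on the series, on what has been measured and on what is new or still open speak of the compounds shown alone.

Two compounds of the series carry measured numbers. Compound 1 `COc1ccc(C2=NN(C3=NC(=O)/C(=C4\C(=O)Nc5ccc(Br)cc54)S3)C(c3ccc(Cl)cc3)C2)cc1` gives 400 nM in a functional assay on cells (Cancer cell lines, Homo sapiens) for cytotoxicity, read by sulforhodamine B assay, with a stated time of 48 h; on this read-out higher numbers stand for weaker inhibition of growth and lower numbers for stronger inhibition of growth. For the measured compounds named here, compound 2 `COc1ccc(-c2cc(-c3ccc(Cl)cc3)n(C3C(=O)Nc4ccc(Br)cc43)n2)cc1` gives 24600 nM in this assay, the higher of the two numbers, with compound 1 standing far lower; no single-point step between them is defined, so the two values are simply noted side by side.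

Compound 3 `COc1ccc(-c2cc(-c3ccc(Cl)cc3)n(C3C(=O)Nc4ccc(Cl)cc43)n2)cc1` is not yet measured. It differs from compound 2 by chloro in place of bromo on an aromatic carbon. With no measured step of this kind in the series, the expectation rests on the change itself: one halogen in place of another, nothing else altered. Expected is a small step, a 1.0-fold higher number from compound 2 to compound 3 (0.01 log units; within the scatter), not beyond the usual scatter in either direction. Compound 3 is accordingly estimated at 25000 nM in this assay, with a range from 8000 nM to 70000 nM.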

Compound 3, concentration for total growth inhibition: 17800 nM
For compound 3 the middle estimate is 1.4-fold (0.15 log units) above the measured one, within the range that was stated.
By their numbers in this assay, from the lowest: compound 1; then compounds 3 and 2 (each within the scatter of the next).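

For the compounds shown here, the step of a 1.4-fold lower number from compound 2 to compound 3 (0.14 log units; within the scatter) in this assay is the first one-place comparison, and it places chloro and bromo on this aromatic carbon within the scatter of each other. At this position of the fused system, on the core shared by compound 2 and compound 3, the two halogens therefore cannot be told apart on this read-out. Nothing on hand offers a reason for this result.

The compounds shown leave open whether a group other than a halogen on this carbon, such as an amine or a carboxylic acid, would give a step beyond the scatter. They also leave open whether chloro in place of bromo would give a similarly small step on the core of compound 1.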